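From a cyano to a difluoro benzyl group

This account rests on a few compounds, and the source may have more. Where it says the series, first, only, none or still open, it means among the compounds named here.

Compound 1 `CN(Cc1nc(C2CCN(Cc3ccccc3F)CC2)no1)c1ncc(C(=O)NO)cn1` gives 98.6 nM
Compound 2 `CN(Cc1nc(C2CCN(Cc3ccc(F)cc3)CC2)no1)c1ncc(C(=O)NO)cn1` gives 22 nM
Compound 3 `CN(Cc1nc(C2CCN(Cc3ccc(C#N)cc3)CC2)no1)c1ncc(C(=O)NO)cn1` gives 117 nM

All three were tested in a functional assay on Raji cells (Homo sapiens) for antiproliferative activity, read by MTT assay, with a stated time of 72 h (a higher number here means a weaker inhibitor, a lower number a stronger inhibitor), where compound 3 stands with 117 nM at the high end of the numbers. It shares that end with compound 1, as the data show a 1.2-fold higher number from compound 1 to compound 3 (0.07 log units; within the scatter) while the other neighbour lies clearly apart, with a 5.3-fold higher number from compound 2 to compound 3 (0.73 log units; beyond the scatter) on exchanging fluoro for cyano.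

The next analogue is compound 4 `CN(Cc1nc(C2CCN(Cc3ccc(F)cc3F)CC2)no1)c1ncc(C(=O)NO)cn1` in which 2,4-difluorophenyl stands in place of 4-cyanophenyl on a saturated chain carbon bound to an amine nitrogen in a ring 2,4-difluorophenyl in place of 4-cyanophenyl on a saturated chain carbon bound to an amine nitrogen in a ring and the rest of the molecule is unchanged.

Going by the values given here, two measured steps bear on this change. Read in reverse, a 5.3-fold higher number from compound 2 to compound 3 (0.73 log units; beyond the scatter) points to a lower number when fluoro returns in place of cyano. Yet a 4.5-fold lower number from compound 1 to compound 2 (0.65 log units; beyond the scatter) shows that not every fluorinated ring matches compound 2, and the new group carries fluorine as both compound 1 and compound 2 do. Among the compounds with values here, no measured compound has two fluorines, so how they combine is unknown. A modest move toward a lower number is therefore expected, and the estimated step in this assay is a 2.6-fold lower number from compound 3 to compound 4 (0.41 log units; beyond the scatter) for this change. The estimate for compound 4 is 45 nM with an expected range from 18 nM to 110 nM before any measurement.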

Compound 4, half-maximal inhibitory concentration: 34.3 nM
For compound 4 the middle estimate is 1.3-fold (0.12 log units) above the measured one; low and high end bracket the measured number.
By their numbers in this assay, from the lowest: compounds 2 and 4 (each within the scatter of the next); then compounds 1 and 3 (each within the scatter of the next).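

In this assay, putting 2,4-difluorophenyl in place of 4-cyanophenyl on the saturated chain carbon gives a 3.4-fold lower number from compound 3 to compound 4 (0.53 log units; beyond the scatter), the first measured step from the nitrile to a ring carrying two fluorines. The step from compound 2 gives a 1.6-fold higher number from compound 2 to compound 4 (0.19 log units; within the scatter), so the fluoro added to 4-fluorophenyl leaves the number within the scatter, whereas the step from compound 1 gives a 2.9-fold lower number from compound 1 to compound 4 (0.46 log units; beyond the scatter), so the fluoro added to 2-fluorophenyl does shift it; among these four compounds, the two whose group names carry a 4-fluoro share the low end, and no compound goes against this. Nothing given here accounts for these steps.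

The compounds shown leave open how a plain benzyl group, with no substituent on its ring, would compare with these fluorinated benzyl groups, and whether a chlorine or a methoxy group on that ring would sit with compound 2 and compound 4 or with compound 1 and compound 3. They also leave open whether this order of the four compounds holds in any read-out other than this assay.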